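The source may hold more compounds than are shown below. What is called first, only, known or untested is meant among the compounds shown, and "the series" means these compounds.

Compound 2 `O=C(CN1CCC(c2cccc[n+]2[O-])CC1)Nc1ccc(F)cc1F` reaches 74% in a functional assay on HEK293 cells for agonist activity at D(4) dopamine receptor (Homo sapiens), read by FLIPR (a higher number here means a larger maximal response, a lower number a smaller maximal response), the highest of the three numbers recorded, though compound 1 `O=C(CN1CCC(c2cccc[n+]2[O-])CC1)Nc1cccc(F)c1` with 70% and compound 3 `Cc1cccc(C(=O)NCN2CCC(c3ccccn3)CC2)c1` with 67% both lie within the scatter of it, so no order among them can be claimed. Compound 4 `O=C(CN1CCC(c2cccc[n+]2[O-])CC1)Nc1cccc(Cl)c1Cl` differs from compound 2 by 2,3-dichlorophenyl in place of 2,4-difluorophenyl on an amide-type nitrogen. For the measured compounds named here, the only measured step that bears on this change, which also swaps one substituted phenyl for another on an amide-type nitrogen, is a number 4 percentage points higher from compound 1 to compound 2 (within the scatter). On that basis the account expects no step beyond the scatter in this assay, and a number 2 percentage points lower from compound 2 to compound 4 (within the scatter) is the estimated step. Compound 4 is therefore expected to give 72%, with a range from 58% to 86%.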

Compound 4, largest response reached (reported as efficacy), in percent of the reference or control that the assay uses: 66%
The estimate for compound 4 lay 6 percentage points above the measured number; the range from low to high includes it.
By their numbers in this assay, from the lowest: compounds 4, 3, 1 and 2 (each within the scatter of the next).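

Two chlorines on this phenyl ring, new among the compounds shown, leave the response in this assay within the scatter of the fluorinated analogues: 2,3-dichlorophenyl on the amide-type nitrogen gives a number 8 percentage points lower from compound 2 to compound 4 (within the scatter) and also a number 4 percentage points lower from compound 1 to compound 4 (within the scatter). So far, this position has accepted both fluorine and chlorine without a step beyond the scatter. No evidence is available to explain these small differences. From the compounds shown here alone, it remains open whether a phenyl ring carrying an amine or a carboxylic acid, or a longer chain in its place, would move the response beyond the scatter.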